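The compounds below may be only part of what the source reports. "The series", "measured", "known", "first", "only" and "open" are said of these compounds alone.

In a functional assay on MDA-MB-435 cells (Homo sapiens) for antiproliferative activity, read by sulforhodamine B assay, with a stated time of 72 h (a higher number here means a weaker inhibitor, a lower number a stronger inhibitor), the measurements so far are:

compound 1 `CCN1C(=O)CS/C1=N/Nc1nncc2ccccc12`: 65 nM
compound 2 `O=S(=O)(Nc1ncccn1)c1ccc(Nc2nncc3ccccc23)cc1`: 45 nM

Compound 2 gives 45 nM and compound 1 gives 65 nM. This gap lies within the usual scatter of repeated measurements, so the numbers do not separate the two compounds.

The unmeasured compound 3 `NS(=O)(=O)c1ccc(Nc2nncc3ccccc23)cc1` differs from compound 2 in one place, with hydrogen in place of pyrimidin-2-yl on a sulfonamide nitrogen. Among the compounds with values here, no measured pair shows this change, so the data offer no direct guide to its size. Compound 1 carries no sulfonamide and gives 65 nM, which suggests that a number of this order does not depend on the pyrimidin-2-yl group. Even so, a sizeable group is leaving, so a moderate rise in this assay is expected, meaning a somewhat weaker inhibitor, and not a collapse in activity. The expected change is a 2.4-fold higher number from compound 2 to compound 3 (0.39 log units; beyond the scatter), though a result within the scatter would be no surprise. For compound 3 the estimated value is 110 nM, with an expected range from 30 nM to 400 nM.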

Compound 3, half-maximal inhibitory concentration: 18 nM
Compound 3: the middle estimate sits 6.1-fold (0.79 log units) above what was measured, and the stated range ends above it.
By their numbers in this assay, from the lowest: compound 3; then compounds 2 and 1 (each within the scatter of the next).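

In this assay, the pyrimidin-2-yl group on the sulfonamide nitrogen proves unnecessary for activity: putting hydrogen in its place gives a 2.5-fold lower number from compound 2 to compound 3 (0.40 log units; beyond the scatter), a modest but real gain in strength. Within the data shown here, this is the first single-place comparison, and it shows that this nitrogen keeps strong activity after the whole ring has gone, with the simpler unsubstituted sulfonamide of compound 3 ahead of the substituted form in compound 2. Nothing in the data accounts for the gain, so the reason for it remains unknown.

With only hydrogen and pyrimidin-2-yl compared on this nitrogen, two end points are known and the ground between them is empty, so a methyl or acetyl group, or a plain phenyl ring, could fall close to either compound 3 or compound 2. On these data alone, it also remains open whether the sulfonamide itself matters, a question that a carboxylic acid or a primary amide in its place on the same benzene ring would address.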